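Methyl to chloro swaps in a small cytotoxicity series

The source may hold more compounds than are shown below. What is called first, only, known or untested is meant among the compounds shown, and "the series" means these compounds.

Three compounds have been run in an ADME assay on MT4 cells (Homo sapiens) for cytotoxicity, read by MTT assay; a lower number here means that less compound is tolerated, a higher number that more compound is tolerated. Compound 1 `O=C(CSc1nccn1-c1cccc2ccccc12)Nc1ccccc1Cl` gives 35200 nM. Compound 2 `Cc1ccc(-n2ccnc2SCC(=O)Nc2ccccc2Cl)cc1` gives 33700 nM in this assay, and compound 3 `Cc1ccccc1NC(=O)CSc1nccn1-c1cccc2ccccc12` gives 34600 nM. All three numbers lie within the usual scatter of one another. The difference between the cores of compound 2 and compound 3 is not broken down here.

One structural change recurs in the set. Going a 1.0-fold higher number from compound 3 to compound 1 (0.01 log units; within the scatter), the change is chloro in place of methyl on an aromatic carbon. The same kind of change, (chloro in place of methyl on an aromatic carbon), leads from compound 2 to the unmeasured compound 4 `O=C(CSc1nccn1-c1ccc(Cl)cc1)Nc1ccccc1Cl`. The two places are not identical: in compound 1 the entering group sits ortho to a large group, in compound 4 it sits para to a large group, so this is the same kind of change rather than the same change.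

The step from compound 2 to compound 4 is expected to be small, a 1.0-fold higher number from compound 2 to compound 4 (0.00 log units; within the scatter), because a 1.0-fold higher number from compound 3 to compound 1 (0.01 log units; within the scatter) lay within the scatter. Compound 4 is accordingly estimated to give 34000 nM in this assay, with a likely range from 20000 nM to 56000 nM.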

Compound 4, half-maximal cytotoxic concentration: > 330000 nM
Compound 4 ended at the assay's limit; the forecaster's own chance of this, stated with the estimate: 10%; middle value at least 9.7-fold (0.98 log units) from the limit.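

In this assay compound 4 reads > 330000 nM, which is a limit of the assay and not a number. Chloro in place of methyl on an aromatic carbon gives an at least 9.7-fold higher number from compound 2 to compound 4 (0.99 log units; beyond the scatter), so this change does not carry over from one core to the other as a constant step: the same change on two cores in this assay, a 1.0-fold higher number (0.01 log units; within the scatter) from compound 3 to compound 1 and an at least 9.7-fold higher number (0.99 log units; beyond the scatter) from compound 2 to compound 4, at least 9.6-fold (0.98 log units) apart, beyond the scatter of two such steps The result does not fix the full size of the step, and with only two pairs, which differ in the place of the change as well as in the core, it does not show which of these sets the gap, nor does it give a rule for other cores in the series: the limit of > 330000 nM in this assay, at which 1 of the 4 values shown sits.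

Open, on these data alone, is how a methoxy group or an amine at the same place on the core of compound 2 would read in this assay, and so whether the large step belongs to chloro alone. Also open, as far as these compounds go, is whether a further methyl to chloro pair on the core of compound 2 would repeat the step or stay within the scatter.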